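The source may hold more compounds than are shown below. What is called first, only, known or untested is meant among the compounds shown, and "the series" means these compounds.

Compound 1 `COc1ccc(NC(=S)NCCNS(=O)(=O)c2sccc2-c2ccc(C)cc2Oc2ccc(O)c(O)c2)cc1` was tested in a functional assay on RS4-11 cells (Homo sapiens) for inhibition, read by CCK-8 assay, with a stated time of 48 h (a lower number here means a stronger inhibitor, a higher number a weaker inhibitor), where compound 1 gives 8300 nM. Among the numbers recorded, this is the highest, yet its nearest neighbour, compound 3 `O=C(NCCNS(=O)(=O)c1ccc(-c2ccccc2Oc2ccc(O)c(O)c2)s1)Nc1cc(C(F)(F)F)cc(C(F)(F)F)c1`, gives 4900 nM in this assay, and the two values lie within the usual scatter, so they cannot be told apart. Compound 2 `COc1ccc(Oc2ccccc2-c2ccsc2S(=O)(=O)N2CCN(C(=S)Nc3ccc([N+](=O)[O-])cc3)CC2)cc1OC` gives only a limit of the assay, > 50000 nM, so that (the limit of > 50000 nM in this assay, at which 1 of the 3 values shown sits). Compound 4 `COc1ccc(NC(=O)NCCNS(=O)(=O)c2sccc2-c2ccc(C)cc2Oc2ccc(O)c(O)c2)cc1` differs from compound 1 in one place: a group of 11 heavy atoms (8 carbon, 1 nitrogen, 2 oxygen; one six-membered aromatic ring of carbon only) in place of a group of 11 heavy atoms (8 carbon, 1 nitrogen, 1 oxygen, 1 sulfur; one six-membered aromatic ring of carbon only), on an amine nitrogen. Among the measured compounds shown here, no measured pair isolates this change, so the step in this assay is expected to be small, in either direction or none beyond the scatter. Compound 4 is therefore estimated at 10000 nM, between 3500 nM and 30000 nM, an expected step of a 1.2-fold higher number from compound 1 to compound 4 (0.08 log units; within the scatter).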

Compound 4, half-maximal inhibitory concentration: 8200 nM
Beside the measured number, compound 4's estimate is 1.2-fold (0.09 log units) above it; measured number inside the range.
By their numbers in this assay, from the lowest: compounds 3, 4 and 1 (each within the scatter of the next). At a limit, above all of these: compound 2.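

In this assay, exchanging the sulfur of the group on this amine nitrogen for oxygen, which gives (4-methoxyphenyl)carbamoyl, brings a 1.0-fold lower number from compound 1 to compound 4 (0.01 log units; within the scatter) and so no readable change. Among the compounds shown here, this is the first pair differing in one place, and it shows that, on this core, this one atom can be exchanged with no difference that can be told apart. Nothing measured here explains why the two compounds match. Still open, on these data alone, is whether an amine or a carboxylic acid in place of the methoxy group would leave the number equally unchanged. Also open, as far as these compounds go, is whether the same exchange behaves alike on a longer chain.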